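A few compounds are considered here, and "the series" means these few. Any claim that something is new, unique, unknown or untested is made for them only; others in the source may bear on it.

Of the compounds shown here, three have so far been measured in a functional assay on KBVIN cells (Homo sapiens) for cytotoxicity, read by sulforhodamine B assay; a lower number here means a stronger inhibitor of growth, a higher number a weaker inhibitor of growth. Compound 1 `Cc1ccc2c(c1)CCCN2c1nc(Cl)nc2ccccc12` gives 46 nM in this assay. Compound 2 `Cc1ccc2c(c1)CCCN2c1nc(C)nc2ccccc12` gives 176 nM in this assay. Compound 3 `COc1ccc2c(c1)CCCCN2c1nc(Cl)nc2ccccc12` gives 197 nM in this assay. Compound 3 is built on a different core from compound 1, and the difference between the two cores is not broken down here; what their values show is that compound 3 gives a higher number than compound 1, beyond the scatter, while compound 3 and compound 2 lie within the scatter of each other.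

Compound 2 differs from compound 1 in one place: methyl in place of chloro on an aromatic carbon. That change produced a 3.8-fold higher number from compound 1 to compound 2 (0.58 log units; beyond the scatter), a weakening of growth inhibition. Compound 4 `COc1ccc2c(c1)CCCCN2c1nc(C)nc2ccccc12`, which has not yet been measured, differs from compound 3 by the same kind of change: methyl in place of chloro on an aromatic carbon. The surroundings of the place are described in the same words for both pairs, so nothing in the recorded structures marks the second case out from the first.

Because the same kind of change gave a 3.8-fold higher number from compound 1 to compound 2 (0.58 log units; beyond the scatter), compound 4 is expected to show a step of similar size, a 3.6-fold higher number from compound 3 to compound 4 (0.55 log units; beyond the scatter), although a single prior example and the separate core of compound 3 leave this expectation loosely held. Compound 4 is therefore estimated at 700 nM, with four of five measurements expected to fall between 300 nM and 1600 nM.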

Compound 4, concentration for 50% growth inhibition: 20 nM
The estimate for compound 4 lay 35-fold (1.54 log units) above the measured number; measured number below the stated range.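

In this assay, methyl in place of chloro on an aromatic carbon gave a 9.9-fold lower number from compound 3 to compound 4 (0.99 log units; beyond the scatter), so the change that weakened growth inhibition on the core of compound 1 strengthened it on the core of compound 3. Set side by side, the two steps run in opposite directions, and the gap between them is larger than repeated measurement would explain, which shows that the result of this change on one core could not be carried over to the other: the same change on two cores in this assay, a 3.8-fold higher number (0.58 log units; beyond the scatter) from compound 1 to compound 2 and a 9.9-fold lower number (0.99 log units; beyond the scatter) from compound 3 to compound 4, 38-fold (1.58 log units) apart, beyond the scatter of two such steps. This does not show which part of the difference between the two cores turns the step around, and with a single pair on each core it gives no general rule for either core or for any further core in the series.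

The compounds shown leave open whether other groups at the same place, between two ring nitrogen atoms, such as an amine, an ethyl group or a longer chain, would follow the direction seen on the core of compound 1 or that seen on the core of compound 3. They also leave open whether the reversal would appear in a compound carrying only part of the difference between the two cores.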